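The source may hold more compounds than are shown below. What is called first, only, known or untested is meant among the compounds shown, and "the series" means these compounds.

Compound 1 `COc1cc(Cl)cc(-c2nn(-c3cccc(NC(=O)Nc4ccc(Cl)c(Cl)c4)c3)cc2-c2ccncc2)c1` and compound 2 `COc1cc(Cl)cc(-c2nn(-c3cccc(NC(=O)Nc4cccc(C(F)(F)F)c4)c3)cc2-c2ccncc2)c1` share one core and differ only in the group on the urea-type nitrogen. In a functional assay on SF-268 cells (Homo sapiens) for inhibition, read by sulforhodamine B assay, with a stated time of 48 h, tested at 100 uM (on this read-out higher numbers stand for a weaker effect at the one concentration tested and lower numbers for a stronger effect), compound 1 gives 11%, while compound 2 gives -28%. That single change, a number 39 percentage points lower from compound 1 to compound 2 (beyond the scatter), puts compound 2 at the lower, stronger end of the two numbers seen so far, with compound 1 the nearest neighbour above it.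

Compound 3 `COc1cc(Cl)cc(-c2nn(-c3cccc(NC(=O)c4cccc(C(F)(F)F)c4)c3)cc2-c2ccncc2)c1` keeps the trifluoromethyl-bearing ring of compound 2 but changes the linker: 3-(trifluoromethyl)phenyl in place of (3-(trifluoromethyl)phenyl)amino on a carbonyl carbon. Going by the values given here, no measured step touches this part of the molecule; the one step known concerns the aryl group, not the carbonyl neighbourhood, so it offers no direct guide. With nothing else to go on, compound 3 is expected to stay close to compound 2, with a step of a number 16 percentage points higher from compound 2 to compound 3 (beyond the scatter) that need not exceed the scatter. Compound 3 is therefore estimated at -12%, within a range from -45% to 25%.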

Compound 3, a percentage reported as activity, at one concentration (the size of the read-out at that concentration, not a potency): 58%
Compound 3: the middle estimate sits 70 percentage points below what was measured; the whole stated range lies below it.
By their numbers in this assay, from the lowest: compound 2; then compound 1; then compound 3.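

Removing the amino unit from the carbonyl carbon, and with it the hydrogen-bond donor counted for that group, gives a number 86 percentage points higher from compound 2 to compound 3 (beyond the scatter) in this assay, so the link to the aryl ring proves to be a sensitive part of the molecule and not merely a spacer. The second comparison, which changes the link and the ring substituents together, gives a number 47 percentage points higher from compound 1 to compound 3 (beyond the scatter) and leaves compound 3 with the weakest effect of the three at the one concentration tested. Nothing available explains this loss of effect.

The compounds shown cannot separate the role of the nitrogen from that of its hydrogen. Going by these compounds, how a methylamino or a methylene unit in the same place would read remains open, as does whether a 3,4-dichlorophenyl group on the shorter link would behave the same way.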